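A Smaller Nitrogen Substituent Tested on a Chloro Analogue

A few compounds are considered here, and "the series" means these few. Any claim that something is new, unique, unknown or untested is made for them only; others in the source may bear on it.

Compound 1 `CC(C)n1c(/C=C2/C(=O)Nc3ccc(Br)cc32)nc2ccccc21` gives 12400 nM in a functional assay on HGC cells (Homo sapiens) for cytotoxicity, read by MTT assay, with a stated time of 48 h; a lower number here means a stronger inhibitor, a higher number a weaker inhibitor. Compound 2 `Cn1c(/C=C2/C(=O)Nc3ccc(Br)cc32)nc2ccccc21` differs from it in one place: methyl in place of isopropyl on an aromatic nitrogen. In this assay compound 2 reaches only a limit of the assay, > 50000 nM. The step of an at least 4.0-fold higher number from compound 1 to compound 2 (0.60 log units; beyond the scatter) therefore rests on a limit (the limit of > 50000 nM in this assay, at which 1 of the 3 values shown sits). Compound 3 `CC(C)n1c(/C=C2/C(=O)Nc3ccc(Cl)cc32)nc2ccccc21` differs from compound 1 in another place: chloro in place of bromo on an aromatic carbon. In this assay compound 3 gives 32800 nM, a step of a 2.6-fold higher number from compound 1 to compound 3 (0.42 log units; beyond the scatter). Compound 4 `Cn1c(/C=C2/C(=O)Nc3ccc(Cl)cc32)nc2ccccc21`, not yet measured, differs from compound 3 by methyl in place of isopropyl on an aromatic nitrogen, the same change seen between compound 1 and compound 2. A weakening at least as large as an at least 4.0-fold higher number from compound 1 to compound 2 (0.60 log units; beyond the scatter) is expected here, so the estimated step is a 4.0-fold higher number from compound 3 to compound 4 (0.60 log units; beyond the scatter). Compound 4 is expected to give 130000 nM, most likely reported only as a limit in this assay.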

Compound 4, half-maximal inhibitory concentration: 43600 nM
Compound 4: middle estimate off by 3.0-fold (0.47 log units), on the high side, outside the stated range (below it).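

Replacing isopropyl with methyl on the aromatic nitrogen does not carry over at a fixed size from the bromo core to the chloro core in this assay, where the new step is a 1.3-fold higher number from compound 3 to compound 4 (0.12 log units; within the scatter): the same change on two cores in this assay, an at least 4.0-fold higher number (0.60 log units; beyond the scatter) from compound 1 to compound 2 and a 1.3-fold higher number (0.12 log units; within the scatter) from compound 3 to compound 4, at least 3.0-fold (0.48 log units) apart, beyond the scatter of two such steps. Replacing bromo with chloro on the aromatic carbon likewise depends on the nitrogen group, with the new step being an at least 1.1-fold lower number from compound 2 to compound 4 (0.05 log units; that floor lies within the scatter): the same change on two cores in this assay, a 2.6-fold higher number (0.42 log units; beyond the scatter) from compound 1 to compound 3 and an at least 1.1-fold lower number (0.05 log units; that floor lies within the scatter) from compound 2 to compound 4, at least 3.0-fold (0.48 log units) apart, beyond the scatter of two such steps. Compound 2 has only a limit of the assay, so both gaps are minimum sizes, and the data do not show why the steps differ: the limit of > 50000 nM in this assay, at which 1 of the 4 values shown sits.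

As far as these compounds go, these four compounds form a single pair of pairs, so a trend across the series remains unknown. From the compounds shown here alone, whether an ethyl group or a longer chain on the nitrogen, or fluoro or methoxy in place of the halogen, would behave similarly also stays open.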